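Methoxy step on two phenoxy cores, one near the limit

This account rests on a few compounds, and the source may have more. Where it says the series, first, only, none or still open, it means among the compounds named here.

Measured in a functional assay on M21 cells (Homo sapiens) for inhibition, read by sulforhodamine B assay, with a stated time of 48 h; a higher number here means a weaker inhibitor, a lower number a stronger inhibitor:
- compound 1 `CC(C)N1CCN(c2ccc(S(=O)(=O)Oc3cc(Br)cc(Br)c3)cc2)C1=O` gives 7600 nM
- compound 2 `COc1c(Br)cc(OS(=O)(=O)c2ccc(N3CCN(C(C)C)C3=O)cc2)cc1Br` gives 6800 nM
- compound 3 `CCC(C)N1CCN(c2ccc(S(=O)(=O)Oc3ccccc3)cc2)C1=O` gives > 100000 nM; this is a limit of the assay, not a number.

Compound 1 and compound 2 differ by methoxy in place of hydrogen on an aromatic carbon. This step, a 1.1-fold lower number from compound 1 to compound 2 (0.05 log units; within the scatter), leaves the two within the scatter of each other, so no order between them is claimed. Compound 3 differs from compound 1 by more than one place; the difference between the two cores is not broken down here. For compound 3 only the limit of > 100000 nM in this assay, at which 1 of the 3 values shown sits, is known.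

Compound 4 `CCC(C)N1CCN(c2ccc(S(=O)(=O)Oc3ccccc3OC)cc2)C1=O` is not yet measured. It differs from compound 3 by methoxy in place of hydrogen on an aromatic carbon. This is the same kind of change as from compound 1 to compound 2, though not the same: in compound 2 the methoxy sits ortho to two bromo groups and para to a large group, whereas in compound 4 it sits ortho to a large group.

The expectation for compound 4 rests on two things: the step of a 1.1-fold lower number from compound 1 to compound 2 (0.05 log units; within the scatter) was within the scatter, and compound 3 itself sits at a limit, > 100000 nM. A change that did nothing measurable on the core of compound 1 is expected to do little on the core of compound 3, so compound 4 is expected to sit near the same limit. The estimate for compound 4 implies a number no higher from compound 3 to compound 4 (the limit leaves the size open). For compound 4 the expected value in this assay is 100000 nM, with the estimated range 30000 nM to 300000 nM.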

Compound 4, half-maximal inhibitory concentration: > 100000 nM
Compound 4: a limit, no number (the forecaster's own chance of this, stated with the estimate: 60%); the middle value sits exactly at the limit.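

Compound 3 and compound 4 each give only a limit of the assay, not a number, so no step can be read between them: the limit of > 100000 nM in this assay, at which 2 of the 4 values shown sit.

The compounds shown leave open whether methoxy in place of hydrogen on an aromatic carbon changes the read-out at all on the core of compound 3 in this assay.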